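The source may hold more compounds than are shown below. What is called first, only, known or untested is meant among the compounds shown, and "the series" means these compounds.

Measured compounds:
compound 1 `O=C1CC(=C(c2ccccc2)c2ccccc2)C(=O)N1CN1CCN(c2ccccc2)CC1`: > 1000 nM
compound 2 `O=C1CC(=C(c2ccccc2)c2ccccc2)C(=O)N1CN1CCN(c2cccc(Cl)c2)CC1`: 392 nM

Among the compounds with values here, in an assay on membranes from Cerebral cortex for binding affinity to Adrenergic receptor alpha-1 (Rattus norvegicus), read by radioligand binding (a lower number here means a stronger inhibitor, a higher number a weaker inhibitor), compound 2 gives 392 nM, the only numeric value in the set. Compound 1 gives > 1000 nM in this assay, which is a limit of the assay and not a number. Within the data shown here, compound 2 therefore stands as the one compound with a measured figure; the other entry is a limit, (the limit of > 1000 nM in this assay, at which 1 of the 2 values shown sits).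

The next compound, compound 3 `O=C1CC(=C(c2ccccc2)c2ccccc2)C(=O)N1CN1CCN(c2ccc(F)cc2)CC1`, differs from compound 2 in one place: 4-fluorophenyl in place of 3-chlorophenyl on an amine nitrogen in a ring. Among the measured compounds shown here, one measured step bears on this: an at least 2.5-fold lower number from compound 1 to compound 2 (0.40 log units; beyond the scatter), where chloro in place of hydrogen on the aromatic carbon lowered the number, with compound 1 sitting at the limit, (the limit of > 1000 nM in this assay, at which 1 of the 2 values shown sits). Going by these compounds, whether a fluorine on the same ring does likewise is untested here. The change from compound 2 to compound 3 exchanges one halogenated phenyl for another, so a modest drift back toward the limit is expected rather than a gain. Compound 3 is expected at 800 nM in this assay, within 300 nM to 2500 nM. This implies an estimated step of a 2.0-fold higher number from compound 2 to compound 3 (0.31 log units; beyond the scatter).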

Compound 3, inhibition constant: 746 nM
Beside the measured number, compound 3's estimate is 1.1-fold (0.03 log units) above it; low and high end bracket the measured number.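

In this assay, 4-fluorophenyl in place of 3-chlorophenyl on the amine nitrogen in the ring gives a 1.9-fold higher number from compound 2 to compound 3 (0.28 log units; within the scatter), so the two halogenated phenyl groups cannot be told apart at this position. Fluoro in place of hydrogen on the aromatic carbon gives an at least 1.3-fold lower number from compound 1 to compound 3 (0.12 log units; that floor lies within the scatter), which does not establish a gain, whereas the chloro change gives an at least 2.5-fold lower number from compound 1 to compound 2 (0.40 log units; beyond the scatter). Compound 1 remains a limit of the assay and not a number, so both changes from it can be read only as floors: the limit of > 1000 nM in this assay, at which 1 of the 3 values shown sits.

The exchange of 3-chlorophenyl for 4-fluorophenyl alters the halogen and its place on the ring together, so these compounds do not separate the two, and they say nothing about a bromo group, a methoxy group or a nitrile on that phenyl ring. Also open, going by these compounds, is whether a pyridine in place of the phenyl ring, or any change to the shared core, would move the number in this assay beyond the scatter.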